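The source may report more compounds than this note shows. Statements on the series, on what has been measured and on what is new or still open speak of the compounds shown alone.

Measured compounds:
compound 1 `CC(=O)c1ccc(-c2nccc3[nH]c(C(C)(C)O)cc23)cc1`: "not determined" (no result reported)
compound 2 `CC(C)(O)c1cc2c(-c3ccc(-c4ccccc4)c(F)c3)nccc2[nH]1`: 9100 nM
compound 3 `CC(C)(O)c1cc2c(-c3ccc(C#N)cc3)nccc2[nH]1`: "not determined" (no result reported)

For the measured compounds named here, in an ADME assay on U2OS cells (Homo sapiens) for cytotoxicity (on this read-out lower numbers stand for higher toxicity in this test and higher numbers for lower toxicity in this test), compound 3 stands with no single number; compound 1 is the one further compound without a number. Only compound 2 gives a number in this assay, and that number is the sole anchor for the series.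

Compound 4 `CC(C)(O)c1cc2c(-c3ccc(F)cc3)nccc2[nH]1` is not yet measured. It differs from compound 3 in one place: fluoro in place of cyano on an aromatic carbon.

Going by the values given here, no step between measured compounds is known, so the size of the step from compound 3 to compound 4 in this assay cannot be read from the data. A small step toward higher numbers, or none beyond the scatter, is expected. For compound 4 the estimate in this assay is 15000 nM, within a range from 5000 nM to 40000 nM.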

Compound 4, half-maximal cytotoxic concentration: 93600 nM
Estimate against measurement, compound 4: 6.2-fold (0.80 log units) below; measured number outside the range, above it.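

In this assay, for the compounds shown here, compound 3 gives "not determined" (no result reported), so no step from compound 3 to compound 4 can be read. No measured evidence bears on this result. The compounds shown leave open how swapping cyano for fluoro shifts this read-out.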